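A few compounds are considered here, and "the series" means these few. Any claim that something is new, unique, unknown or untested is made for them only; others in the source may bear on it.

In an assay on blood for inhibition of Indoleamine 2,3-dioxygenase 1 (Homo sapiens) (on this read-out lower numbers stand for stronger inhibition and higher numbers for weaker inhibition), compound 1 `O=C(OC1CC1)N1CCc2cc(C3(C(=O)Nc4ccc(F)cc4)CCC3)ccc21` gives 41 nM, compound 2 `Cc1nccc(N2CCc3nc(C4(C(=O)Nc5ccc(F)cc5)CCC4)ccc32)n1` gives 430 nM and compound 3 `O=C(C1CC1)N1CCc2nc(C3(C(=O)Nc4ccc(F)cc4)CCC3)ccc21` gives 330 nM. Going by the values given here, compound 3 thus stands second highest of the three numbers, with compound 2 as its nearest neighbour and compound 1 as the furthest; the only step between two compounds differing in one place, a 1.3-fold lower number from compound 2 to compound 3 (0.11 log units; within the scatter), lies within the scatter. The step to compound 4 `O=C(c1cccc(Cl)c1)N1CCc2nc(C3(C(=O)Nc4ccc(F)cc4)CCC3)ccc21` alters the group on the carbonyl carbon: 3-chlorophenyl in place of cyclopropyl on a carbonyl carbon. Among the compounds with values here, no measured step exchanges a group on that carbonyl, so nothing bears on it directly; the one step that does touch the nitrogen on the aromatic ring in a ring was small, and compound 2 and compound 3 give numbers within the scatter of each other. Compound 4 is therefore expected to show no step beyond the scatter, a 1.1-fold lower number from compound 3 to compound 4 (0.04 log units; within the scatter), because a 1.3-fold lower number from compound 2 to compound 3 (0.11 log units; within the scatter) itself stayed within the scatter. Compound 4 is estimated at 300 nM, between 100 nM and 1000 nM.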

Compound 4, half-maximal inhibitory concentration: 93 nM
Compound 4: middle estimate off by 3.2-fold (0.51 log units), on the high side, outside the stated range (below it).
By their numbers in this assay, from the lowest: compound 1; then compound 4; then compounds 3 and 2 (each within the scatter of the next).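

In this assay the group on the carbonyl carbon turns out to matter: 3-chlorophenyl in place of cyclopropyl gives a clear step (a 3.5-fold lower number from compound 3 to compound 4 (0.55 log units; beyond the scatter)), whereas the earlier exchange on the same nitrogen (a 1.3-fold lower number from compound 2 to compound 3 (0.11 log units; within the scatter)) stayed within the scatter. The (3-chlorophenyl)carbonyl group also separates from 2-methylpyrimidin-4-yl on that nitrogen (a 4.6-fold lower number from compound 2 to compound 4 (0.66 log units; beyond the scatter)), so the small earlier step did not mean that this position is indifferent to what it carries. Nothing available explains why the number falls with this change.

The compounds shown leave open whether the gain needs the chlorine or its place on the ring, which an unsubstituted phenyl or a 4-chlorophenyl group would test. They also leave open how a carbonyl group bearing an amine or a carboxylic acid-substituted phenyl would read out on this core.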